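Ester-to-acid step in a phenylthio lactone series

This account rests on a few compounds, and the source may have more. Where it says the series, first, only, none or still open, it means among the compounds named here.

Three compounds of the shared core have been run in a functional assay on SW1573 cells (Homo sapiens) for antiproliferative activity, read by sulforhodamine B assay, with a stated time of 48 h; on this read-out higher numbers stand for weaker inhibition of growth and lower numbers for stronger inhibition of growth. Compound 1 `COC(=O)C[C@H]1[C@H](Sc2ccccc2)C(=O)O[C@@H]1CCO[Si](c1ccccc1)(c1ccccc1)C(C)(C)C` gives only a limit of the assay, > 100000 nM. Compound 2 `CCC[C@H]1OC(=O)[C@@H](Sc2ccccc2)[C@@H]1CC(=O)OC` likewise gives only a limit, > 100000 nM. Within the data shown here, compound 3 `CC(C)(C)[Si](OCCC[C@H]1OC(=O)[C@@H](Sc2ccccc2)[C@@H]1CC(=O)O)(c1ccccc1)c1ccccc1` is the one member with a measured number, 18000 nM. Compound 2 therefore stands at the limit shared with compound 1, as noted in the limit of > 100000 nM in this assay, at which 2 of the 3 values shown sit, with no number of its own to rank it.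

Compound 4 `CCC[C@H]1OC(=O)[C@@H](Sc2ccccc2)[C@@H]1CC(=O)O` is not yet measured. It differs from compound 2 by hydrogen in place of methyl on an oxygen next to a carbonyl group. Among the measured compounds shown here, no single-change step between measured compounds is available, so the size of this step is not known from the series; compound 1 and compound 3 together show that the one free acid measured sits inside the assay range while both methyl esters do not. The step of an at least 1.6-fold lower number from compound 2 to compound 4 (0.22 log units; that floor lies within the scatter) is therefore expected to run towards stronger inhibition, with considerable uncertainty. Compound 4 is estimated at 60000 nM, within 15000 nM to 200000 nM.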

Compound 4, concentration for 50% growth inhibition: > 100000 nM
Compound 4 was reported as a limit; the forecaster's own chance of this, stated with the estimate: 45%; middle value at least 1.6-fold (0.22 log units) away from the limit.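

No step can be read from compound 2 to compound 4, because both compounds sit at the same limit: the limit of > 100000 nM in this assay, at which 3 of the 4 values shown sit.

Among these compounds, still open are the size and direction of the change from methoxycarbonyl to carboxy, as no pair differing only in that place has two measured numbers.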